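Shortening the Acid Chain: Two Parallel Steps

The compounds below may be only part of what the source reports. "The series", "measured", "known", "first", "only" and "open" are said of these compounds alone.

Compound 1 `O=C(O)CN1Cc2ccc(NC(=O)c3ccc(C4CCNCC4)cc3)cc2C1=O`: 24000 nM
Compound 2 `O=C(O)CCCN1Cc2ccc(NC(=O)CC3CCNCC3)cc2C1=O`: 1800 nM
Compound 3 `O=C(O)CCCN1Cc2ccc(NC(=O)c3ccc(C4CCNCC4)cc3)cc2C1=O`: 410000 nM

Of the compounds shown here, three have been measured in a functional assay on a cell-free system (Platelet, plasma, Homo sapiens) for inhibition; a higher number here means a weaker inhibitor, a lower number a stronger inhibitor. Compound 3 gives the highest number, 410000 nM, and compound 1 the next, 24000 nM. The change from compound 3 to compound 1 is carboxy in place of 2-carboxyethyl on a saturated chain carbon bound to an amide-type nitrogen in a ring. That change made the step of a 17-fold lower number from compound 3 to compound 1 (1.23 log units; beyond the scatter). Compound 2 gives the lowest of the three numbers, 1800 nM; the difference between the core of compound 2 and the core of compound 3 is not broken down here.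

Compound 4 `O=C(O)CN1Cc2ccc(NC(=O)CC3CCNCC3)cc2C1=O` is not yet measured. It differs from compound 2 by carboxy in place of 2-carboxyethyl on a saturated chain carbon bound to an amide-type nitrogen in a ring, the same change as from compound 3 to compound 1, at the same place. Since that earlier change made a large step, a step of similar direction is expected here, though it rests on a single pair and the core of compound 2 is not the core of compound 3. Compound 4 is therefore estimated at 200 nM, between 50 nM and 1000 nM, a step of a 9.0-fold lower number from compound 2 to compound 4 (0.95 log units; beyond the scatter).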

Compound 4, half-maximal inhibitory concentration: 51000 nM
Estimate against measurement, compound 4: 260-fold (2.41 log units) below; the whole stated range lies below it.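

In this assay, the change from 3-carboxypropyl to carboxymethyl gives a 28-fold higher number from compound 2 to compound 4 (1.45 log units; beyond the scatter), so the shorter acid chain does not bring a lower number on every core. Among these compounds, the same change therefore runs in opposite directions on the two cores: the same change on two cores in this assay, a 17-fold lower number (1.23 log units; beyond the scatter) from compound 3 to compound 1 and a 28-fold higher number (1.45 log units; beyond the scatter) from compound 2 to compound 4, 480-fold (2.68 log units) apart, beyond the scatter of two such steps This shows that the result of the change on one core could not be carried over to the other, but with only one pair for each core, it does not show which part of the cores sets the direction or how the change would turn out on a third core.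

The compounds shown leave open how the number would move on either core with a still longer acid chain, or with an ester in place of the carboxylic acid. They also leave open whether the reversal would persist if the ring amine were replaced by an open-chain amine.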